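The source may hold more compounds than are shown below. What is called first, only, known or untested is meant among the compounds shown, and "the series" means these compounds.

The measured compounds:
Compound 1 `CC(=O)Oc1cccc2cc(-c3ccccc3)c(=O)oc12` in a functional assay on CHO cells for antagonist activity at adenosine receptor A2b (Homo sapiens), read by cAMP accumulation (a lower number here means a stronger inhibitor, a higher number a weaker inhibitor), gives only a limit, > 30000 nM.
Compound 2 `CC(=O)Oc1ccc2cc(-c3ccccc3)c(=O)oc2c1OC(C)=O` in this assay likewise gives only a limit, > 30000 nM.
Compound 3 `CC(=O)Oc1ccc(-c2cc3cccc(OC(C)=O)c3oc2=O)cc1OC(C)=O` in this assay also gives only a limit, > 30000 nM.

From compound 1 to compound 2 the change is acetoxy in place of hydrogen on an aromatic carbon; the step it made, a step that the two limits leave unreadable from compound 1 to compound 2, is left unreadable by the two limits. The difference between the cores of compound 1 and compound 3 is not broken down here. Compound 4 `CC(=O)Oc1ccc(-c2cc3ccc(OC(C)=O)c(OC(C)=O)c3oc2=O)cc1OC(C)=O` is not yet measured; it differs from compound 3 by acetoxy in place of hydrogen on an aromatic carbon, the same change as from compound 1 to compound 2, made in the same surroundings. Within the data shown here, all three measured values sit at the limit of > 30000 nM in this assay, at which 3 of the 3 values shown sit, and the one measured instance of the change did not move a value off that limit. On that footing compound 4 is expected in this assay to give about 30000 nM, with a range from 10000 nM to 100000 nM, most likely reported only as a limit. The step this estimate means is expected to be essentially none, a number no higher from compound 3 to compound 4 (the limit leaves the size open), resting on a step that the two limits leave unreadable from compound 1 to compound 2.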

Compound 4, half-maximal inhibitory concentration: > 30000 nM
Compound 4: no number, only a limit (the forecaster's own chance of this, stated with the estimate: 85%); the middle value lies on the limit itself.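

Compound 3 and compound 4 both give only limits in this assay, so the step between them cannot be read. The compounds shown leave open whether acetoxy in place of hydrogen on an aromatic carbon changes the inhibition at all, or how strongly any of them inhibits, since every value is a limit: the limit of > 30000 nM in this assay, at which 4 of the 4 values shown sit.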